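This account rests on a few compounds, and the source may have more. Where it says the series, first, only, none or still open, it means among the compounds named here.

In a functional assay, read by spectrophotometry, tested at 100 uM (on this read-out lower numbers stand for stronger inhibition and higher numbers for weaker inhibition), compound 1 (`O=C(/C=C/c1ccc(F)cc1)c1cccc(NC(=O)c2cc(-c3ccncc3)n[nH]2)c1`) gives 58700 nM while compound 2 (`O=C(/C=C/c1ccc(Cl)cc1)c1cccc(NC(=O)c2cc(-c3ccncc3)n[nH]2)c1`) gives 78900 nM and compound 3 (`O=C(/C=C/c1ccc([N+](=O)[O-])cc1)c1cccc(NC(=O)c2cc(-c3ccncc3)n[nH]2)c1`) gives 64600 nM on the same scale. Compound 3 therefore stands level with the other two, and the three exchanges on the aromatic carbon show a 1.3-fold higher number from compound 1 to compound 2 (0.13 log units; within the scatter) as well as a 1.1-fold higher number from compound 1 to compound 3 (0.04 log units; within the scatter) and a 1.2-fold lower number from compound 2 to compound 3 (0.09 log units; within the scatter) without any separation among the compounds.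

The next compound is compound 4 (`COc1ccccc1/C=C/C(=O)c1cccc(NC(=O)c2cc(-c3ccncc3)n[nH]2)c1`), which has 2-methoxyphenyl in place of 4-nitrophenyl on a double-bonded chain carbon bound to a double-bonded chain carbon is the counted difference. For the measured compounds named here, none of the measured compounds carries a 2-methoxyphenyl group, so the measured steps bear on this change only indirectly. They do show that fluoro, chloro and nitro leave the numbers flat, as in a 1.1-fold higher number from compound 1 to compound 3 (0.04 log units; within the scatter) for compound 3. The expected result is a 1.0-fold higher number from compound 3 to compound 4 (0.00 log units; within the scatter) and no shift beyond the scatter is expected, though the untested group leaves a wide range. In this assay compound 4 is expected at 65000 nM (estimated range 30000 nM to 120000 nM).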

Compound 4, half-maximal inhibitory concentration: 56700 nM
The estimate for compound 4 lay 1.1-fold (0.06 log units) above the measured number; the range from low to high includes it.
By their numbers in this assay, from the lowest: compounds 4, 1, 3 and 2 (each within the scatter of the next).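

In this assay, for the compounds shown here, 2-methoxyphenyl in place of a 4-substituted phenyl group on a double-bonded chain carbon bound to a double-bonded chain carbon gives a 1.1-fold lower number from compound 3 to compound 4 (0.06 log units; within the scatter) and a 1.4-fold lower number from compound 2 to compound 4 (0.14 log units; within the scatter) and a 1.0-fold lower number from compound 1 to compound 4 (0.02 log units; within the scatter) with no separation among the compounds. The earlier compounds shown here had varied only fluoro, chloro and nitro on the aromatic carbon, whereas this exchange replaces the whole 4-substituted phenyl group and still leaves all four compounds level. No evidence is available that would account for this flat response.

From the compounds shown here alone, whether an amine or a carboxylic acid on the phenyl ring, or a longer chain in place of the 2-(2-methoxyphenyl)ethenyl group, would stand apart from these compounds remains open. Going by these compounds, it also remains open whether the shared core, rather than this group, sets the level of all four.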